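The source may report more compounds than this note shows. Statements on the series, on what has been measured and on what is new or still open speak of the compounds shown alone.

In a physicochemical assay, read by spectrophotometry, with a stated time of 60 min (a higher number here means a weaker inhibitor, a lower number a stronger inhibitor), compound 1 `COc1ccccc1Nc1nnc(CSCc2cc(C(C)(C)C)c(O)c(C(C)(C)C)c2)s1` gives 90800 nM and compound 2 `COc1ccc(-n2c(S)nnc2CSCc2cc(C(C)(C)C)c(O)c(C(C)(C)C)c2)cc1` gives 92700 nM in the same read-out, so compound 1 stands level with compound 2, within the usual scatter of such measurements. Compound 3 `COc1ccc(Nc2nnc(CSCc3cc(C(C)(C)C)c(O)c(C(C)(C)C)c3)s2)cc1` has not yet been measured. The structural change from compound 1 to compound 3 reads 4-methoxyphenyl in place of 2-methoxyphenyl on a nitrogen on an aromatic ring and amounts to 4-methoxyphenyl in place of 2-methoxyphenyl on a nitrogen on an aromatic ring, with the same atoms joined differently. Among the compounds with values here, no measured pair shows this change, so nothing sets a direction in this assay and no step beyond the scatter is expected. Compound 1 at 90800 nM is therefore the anchor for the expectation. The estimated step is a 1.1-fold lower number from compound 1 to compound 3 (0.03 log units; within the scatter) and is expected to stay within the scatter. For compound 3 the estimate is 85000 nM with an expected range from 35000 nM to 200000 nM in this read-out.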

Compound 3, half-maximal inhibitory concentration: 76800 nM
Estimate against measurement, compound 3: 1.1-fold (0.04 log units) above; low and high end bracket the measured number.
By their numbers in this assay, from the lowest: compounds 3, 1 and 2 (each within the scatter of the next).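

In this assay, 4-methoxyphenyl in place of 2-methoxyphenyl on a nitrogen on an aromatic ring gives a 1.2-fold lower number from compound 1 to compound 3 (0.07 log units; within the scatter). Within the data shown here, this is the first pair that differs in one place, and it shows that these two methoxyphenyl isomers stand level in this read-out, with no step beyond the scatter. No measurement bears on the result, so the data offer no account of this outcome.

Going by these compounds, what stays open is whether any other group at this place moves the number beyond the scatter, for example a phenyl carrying a carboxylic acid or an amine instead of methoxy, or a plain phenyl. Among these compounds, with only this one step available, no direction is yet set at this position.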